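Methoxy position on the aniline of the shared core

A few compounds are considered here, and "the series" means these few. Any claim that something is new, unique, unknown or untested is made for them only; others in the source may bear on it.

Compound 1 `COc1cccc(NC2=CC(=O)c3c(nc4n3[C@H]3OC[C@@H](O)[C@H]3OC4)C2=O)c1` is tested in a functional assay on HeLa cells (Homo sapiens) for inhibition, read by sulforhodamine B assay (a higher number here means a weaker inhibitor, a lower number a stronger inhibitor), where it gives only a limit of > 8000 nM. Of the three values shown, one sits at this limit (the limit of > 8000 nM in this assay, at which 1 of the 3 values shown sits), so where compound 1 stands among the numbers is known only as the weak end of the set. Compound 2 `Cc1ccc(NC2=CC(=O)c3nc4n(c3C2=O)[C@H]2OC[C@@H](O)[C@H]2OC4)cc1C` gives 2690 nM in this assay, and compound 3 `COc1cccc(NC2=CC(=O)c3nc4n(c3C2=O)[C@H]2OC[C@@H](O)[C@H]2OC4)c1` gives 4280 nM. For the measured compounds named here, the one measured step, a 1.6-fold higher number from compound 2 to compound 3 (0.20 log units; within the scatter), concerns a different change and a differently built core, and it stays within the scatter.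

Compound 4 `COc1ccccc1NC1=CC(=O)c2c(nc3n2[C@H]2OC[C@@H](O)[C@H]2OC3)C1=O` differs from compound 1 as 2-methoxyphenyl in place of 3-methoxyphenyl on an amine nitrogen. Going by the values given here, no measured step concerns the position of the methoxy group on the phenyl ring of the amine, so nothing in the set predicts the direction of this change, and the only anchor is the limit given by compound 1. Compound 4 is therefore expected to remain weak in this assay, with the estimate 9000 nM spanning 3000 nM to 30000 nM. Taken as a step, this estimate corresponds to a step that the limit leaves unreadable from compound 1 to compound 4, and a report of only a limit for compound 4 is judged about as likely as a numerical value.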

Compound 4, half-maximal inhibitory concentration: 7460 nM
For compound 4 the middle estimate is 1.2-fold (0.08 log units) above the measured one; the measured number falls inside the stated range.
By their numbers in this assay, from the lowest: compounds 2, 3 and 4 (each within the scatter of the next, the first and the last beyond it). At a limit, above all of these: compound 1.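

In this assay, for the compounds shown here, compound 4 gives 7460 nM, the first actual number on this core, so the (2-methoxyphenyl)amino group places the core on the measurable scale. Compound 1 gives only a limit, > 8000 nM. Moving the methoxy group from the 3-methoxyphenyl to the 2-methoxyphenyl arrangement on the amine nitrogen gives an at least 1.0-fold lower number from compound 1 to compound 4 (0.03 log units; that floor lies within the scatter), so the data establish no real effect of this change, and its true size remains unreadable because one end of the step is censored: the limit of > 8000 nM in this assay, at which 1 of the 4 values shown sits.

Still open, from the compounds shown here alone, is how the core of compound 1 responds to anything other than a methoxy group on this phenyl ring, such as an unsubstituted phenyl, the 3,4-dimethylphenyl group, an amine or a carboxylic acid. Also open is whether any such replacement on the amine nitrogen would move the number on this core clearly beyond the scatter, since the two compounds shown on it offer only one number and one limit to compare.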